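The compounds below may be only part of what the source reports. "The series", "measured", "known", "first", "only" and "open" are said of these compounds alone.

Of the compounds shown here, two have so far been measured in a physicochemical assay for lipophilicity, read by HPLC, measured as octanol-water partition, at pH 7.4; on this read-out higher numbers stand for higher lipophilicity and lower numbers for lower lipophilicity. Compound 1 `CC1(C)C[C@H](CN([C@H](CCC(F)(F)F)C(N)=O)S(=O)(=O)c2ccc(Cl)cc2)O1` gives 3.8, and compound 2 `NC(=O)[C@@H](CCC(F)(F)F)N(C[C@H]1CCOC1)S(=O)(=O)c1ccc(Cl)cc1` gives 2.8. Among the compounds with values here, the one measured step is a number 1.00 log units lower from compound 1 to compound 2 (beyond the scatter), which puts compound 2 at the lower of the two numbers, with compound 1 the nearest comparison.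

Compound 3 `NC(=O)[C@@H](CCC(F)(F)F)N(C[C@@H]1CCOC1)S(=O)(=O)c1ccc(Cl)cc1` is the next compound to be measured in this assay. It differs from compound 2 in that (the two compounds have the same atoms and bonds and differ only in configuration as drawn: 1 of 2 stereo elements differ; a stereocentre at a saturated ring carbon is drawn R in compound 2 and S in compound 3). The measured step between compound 1 and compound 2 involved a different ring, so it does not bear directly on this change. Within the data shown here, nothing among the measured compounds shows what a change of configuration alone does here, and with the same atoms and bonds on both sides no step beyond the scatter is expected in this assay.

Compound 3 is therefore expected to give about 2.8, within a range of 2.5 to 3.1. The step from compound 2 to compound 3 is estimated as no change at the digits printed from compound 2 to compound 3 (within the scatter).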

Compound 3, distribution coefficient: 2.8
Compound 3: middle estimate and measured number agree at the digits printed; measured number inside the range.
By their numbers in this assay, from the lowest: compounds 2 and 3 (each within the scatter of the next); then compound 1.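

In this assay, changing the stereocentre at the saturated ring carbon from R to S gives no change at the digits printed from compound 2 to compound 3 (within the scatter), so at this position the drawn configuration of the oxolan-3-yl group leaves the read-out within the scatter. The ring exchange now holds for both configurations: oxolan-3-yl in place of 4,4-dimethyloxetan-2-yl gives a number 1.00 log units lower from compound 1 to compound 3 (beyond the scatter), the same size as the step already seen for the other configuration. This pair is a clean test of configuration alone because of how the two structures relate: the fact that compounds 2 and 3 differ only in the configuration as drawn

The compounds shown leave open what the other stereo element does, as it is drawn alike in compound 2 and compound 3. They also leave open what an amine on the ring, or a longer chain in place of the ring, would do in this assay.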